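Sulfonamide series: heteroaryl swap on the sulfonyl sulfur

A few compounds are considered here, and "the series" means these few. Any claim that something is new, unique, unknown or untested is made for them only; others in the source may bear on it.

Measured compounds:
Compound 1 `O=S(=O)(Nc1ccc(-c2nc3ccccc3o2)cc1)c1cccs1` in an assay on isolated protein for inhibition of malate dehydrogenase, mitochondrial (Sus scrofa), with stated times of 45 min and 30 min (on this read-out higher numbers stand for weaker inhibition and lower numbers for stronger inhibition), gives > 63000 nM, which is a limit of the assay and not a number.
Compound 2 `COc1ccc(S(=O)(=O)Nc2ccc(-c3nc4ccccc4o3)cc2)cc1` in this assay gives > 63000 nM, again a limit of the assay.
Compound 3 `Cc1ccccc1S(=O)(=O)Nc1ccc(-c2nc3ccccc3o2)cc1` in this assay gives > 63000 nM, also a limit of the assay.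

Compound 3 therefore stands at the limit, where all three values shown sit, as recorded in the limit of > 63000 nM in this assay, at which 3 of the 3 values shown sit. The steps among the measured compounds cannot be read: a step that the two limits leave unreadable from compound 1 to compound 2, a step that the two limits leave unreadable from compound 1 to compound 3 and a step that the two limits leave unreadable from compound 2 to compound 3 are all left unreadable by the two limits.

The next compound, compound 4 `O=S(=O)(Nc1ccc(-c2nc3ccccc3o2)cc1)c1ccc(Cl)s1`, differs from compound 3 as follows: 5-chlorothiophen-2-yl in place of 2-methylphenyl on a sulfonyl sulfur. Among the compounds with values here, no measured step bears on this change, since every step in the set is unreadable and every value is a limit. With three limits and no readable step, no direction and no size can be drawn from the data, and the expectation rests only on the fact that compound 3 and its two neighbours sit at the limit.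

Compound 4 is therefore expected to return a value at or near the limit as well, estimated at 100000 nM with a range of 20000 nM to 500000 nM. The estimated step that the limit leaves unreadable from compound 3 to compound 4 is expected to be none beyond the scatter.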

Compound 4, half-maximal inhibitory concentration: > 63000 nM
Compound 4: a limit, no number; the forecaster's own chance of this, stated with the estimate: 85%; the middle value lies beyond the limit too.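

Compound 4 also returns a limit of the assay and not a number, so its steps from compound 1, compound 2 and compound 3 cannot be read in this assay, and the series now stands as follows: the limit of > 63000 nM in this assay, at which 4 of the 4 values shown sit.

The compounds shown leave open how strongly any of the four inhibits, and whether the group on the sulfonyl sulfur affects inhibition at all.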